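Acylaminopyrrolidine in place of bridged diamine on shared core

The source may hold more compounds than are shown below. What is called first, only, known or untested is meant among the compounds shown, and "the series" means these compounds.

Measured so far in a functional assay on HEK293 cells for activation of melanin-concentrating hormone receptor 1 (Rattus norvegicus), read by inositol phosphate accumulation; on this read-out higher numbers stand for an effect only at larger amounts of compound and lower numbers for an effect already at smaller amounts:
compound 1 `O=C(CCc1ccc(C(F)(F)F)cc1)Nc1ccc2nc(N3CCC(NS(=O)(=O)O)C3)ccc2c1`: 50 nM
compound 2 `CC(C)N(C)c1ccc2cc(NC(=O)CCc3ccc(C(F)(F)F)cc3)ccc2n1`: 140 nM
compound 3 `O=C(CCc1ccc(C(F)(F)F)cc1)Nc1ccc2nc(N3CC4CC3CN4)ccc2c1`: 490 nM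

Compound 3 stands highest of the three numbers; the steps of a 9.8-fold higher number from compound 1 to compound 3 (0.99 log units; beyond the scatter) and a 3.5-fold higher number from compound 2 to compound 3 (0.54 log units; beyond the scatter) both lie beyond the scatter. Compound 4 `CC(C)C(=O)NC1CCN(c2ccc3cc(NC(=O)CCc4ccc(C(F)(F)F)cc4)ccc3n2)C1` carries a group of 11 heavy atoms (8 carbon, 2 nitrogen, 1 oxygen; one five-membered non-aromatic ring with 1 hetero atom) in place of a group of 7 heavy atoms (5 carbon, 2 nitrogen; 2 five-membered non-aromatic rings with 1 hetero atom each), on an aromatic carbon. Going by the values given here, the nearest precedent is the step of a 9.8-fold higher number from compound 1 to compound 3 (0.99 log units; beyond the scatter), since compound 1 also bears a pyrrolidin-1-yl with a hydrogen-bond donor on the ring; the step of a 2.8-fold higher number from compound 1 to compound 2 (0.45 log units; beyond the scatter) shows a smaller pyrrolidine-free group still beating compound 3. Compound 4 is therefore expected to return toward the lower numbers, an estimated 6.1-fold lower number from compound 3 to compound 4 (0.79 log units; beyond the scatter). For compound 4 the estimate in this assay is 80 nM, with a range from 25 nM to 250 nM.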

Compound 4, half-maximal effective concentration: 90 nM
The estimate for compound 4 lay 1.1-fold (0.05 log units) below the measured number; low and high end bracket the measured number.
By their numbers in this assay, from the lowest: compounds 1, 4 and 2 (each within the scatter of the next, the first and the last beyond it); then compound 3.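

In this assay, 3-((isopropylcarbonyl)amino)pyrrolidin-1-yl in place of the bridged diamine on the aromatic carbon next to the ring nitrogen gives a clear step (a 5.4-fold lower number from compound 3 to compound 4 (0.74 log units; beyond the scatter)). Isopropylcarbonyl in place of sulfo on the amine nitrogen stays within the scatter (a 1.8-fold higher number from compound 1 to compound 4 (0.26 log units; within the scatter)), as does the exchange with isopropyl(methyl)amino (a 1.6-fold lower number from compound 2 to compound 4 (0.19 log units; within the scatter)), so among these four compounds only compound 3 stands apart at this position. No measurement shown accounts for these differences.

Open, as far as these compounds go, is how a free amine or a longer acyl chain on that amine nitrogen would read in this assay.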